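The source may report more compounds than this note shows. Statements on the series, on what has been measured and on what is new or still open speak of the compounds shown alone.

Compound 1 `COc1ccc(C(=O)Nc2cccc(NC(=O)COc3ccc4c(=O)ccoc4c3)c2)cc1` gives 7 nM in an assay on isolated protein for inhibition of Rho-associated protein kinase 2 (Homo sapiens), read by scintillation counting, radiometric assay and 33P incorporation, with a stated time of 40 min, in the presence of a further agent that is not named here; on this read-out higher numbers stand for weaker inhibition and lower numbers for stronger inhibition.
Compound 2 `CCOc1ccc(C(=O)Nc2cccc(NC(=O)COc3ccc4c(=O)ccoc4c3)c2)cc1` gives 9 nM in this assay.

Compound 2 and compound 1 lie within the scatter of each other, as a 1.3-fold higher number from compound 1 to compound 2 (0.11 log units; within the scatter) shows. Compound 3 `CC(C)(C)c1cc(C(=O)Nc2cccc(NC(=O)COc3ccc4c(=O)ccoc4c3)c2)no1` carries 5-(tert-butyl)-1,2-oxazol-3-yl in place of 4-ethoxyphenyl on a carbonyl carbon. Going by the values given here, the only measured step, a 1.3-fold higher number from compound 1 to compound 2 (0.11 log units; within the scatter), changes just the small alkyl on the ether oxygen, so no measured step bears on swapping the whole aromatic ring. Compound 3 is therefore expected to show a 2.2-fold higher number from compound 2 to compound 3 (0.35 log units; beyond the scatter), with wide uncertainty. The estimate for compound 3 is 20 nM, in a range from 5 nM to 80 nM.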

Compound 3, half-maximal inhibitory concentration: 5 nM
Estimate against measurement, compound 3: 4.0-fold (0.60 log units) above; low and high end bracket the measured number.
By their numbers in this assay, from the lowest: compounds 3, 1 and 2 (each within the scatter of the next).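

On the carbonyl carbon, 5-(tert-butyl)-1,2-oxazol-3-yl can replace a whole 4-ethoxyphenyl (a 1.8-fold lower number from compound 2 to compound 3 (0.26 log units; within the scatter)) or its 4-methoxyphenyl counterpart (a 1.4-fold lower number from compound 1 to compound 3 (0.15 log units; within the scatter)), and both steps stay within the scatter. The earlier step altered only the small alkyl on the ether oxygen, whereas here a six-membered aromatic ring of carbon only gives way to a five-membered aromatic ring with 2 hetero atoms. Nothing measured here explains this closeness.

Still open, as far as these compounds go, is how much the tert-butyl matters, which a methyl in its place would test. Also open, from the compounds shown here alone, is whether a ring carrying an amine or a carboxylic acid would fit this carbonyl carbon equally well.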